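Solubility notes on a shared-core series: compounds 1 to 4

The source may report more compounds than this note shows. Statements on the series, on what has been measured and on what is new or still open speak of the compounds shown alone.

Measured so far:
compound 1 `Cc1noc(-c2nc(C)c3c(c2N)C(=O)N(Cc2ccc(Oc4ccc(F)cc4)cc2)C3=O)n1`: 23800 nM
compound 2 `Cc1noc(-c2nc(C)c3c(c2N)C(=O)N(CC2CCOCC2)C3=O)n1`: 5700 nM
compound 3 `Cc1noc(-c2nc(C)c3c(c2N)C(=O)N(Cc2ccccc2F)C3=O)n1`: limit, < 5000 nM

In a physicochemical assay for solubility, using the shake flask method, in simulated intestinal fluid, measured as kinetic solubility, with a stated time of 2 h, at 25 degrees C, at pH 6.5 (on this read-out lower numbers stand for lower solubility and higher numbers for higher solubility), compound 1 gives 23800 nM and stands highest of the two numbers reported. The nearest number is that of compound 2, which in this assay gives 5700 nM; the gap between compound 1 and compound 2 lies beyond the scatter. Compound 3 reaches only the limit of this assay, (the limit of < 5000 nM in this assay, at which 1 of the 3 values shown sits), and no number is known for it.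

Among the measured compounds shown here, the only step between compounds differing in one place is an at least 1.1-fold lower number from compound 2 to compound 3 (0.05 log units; that floor lies within the scatter); its floor lies within the scatter, and it concerns the group on the saturated chain carbon bound to the amide-type nitrogen, not the aromatic ring that compound 4 alters.

Compound 4 `Cc1noc(-c2nc(C)c3c(c2N)C(=O)N(Cc2ccc(C#N)cc2)C3=O)n1` is not yet measured. It differs from compound 1 as follows: cyano in place of 4-fluorophenoxy on an aromatic carbon. For the measured compounds named here, no measured step covers this kind of change, so the direction of any move from compound 1 cannot be read from the data; a step of uncertain sign, possibly no larger than the scatter, is expected.

Compound 4 is therefore estimated at 14000 nM in this assay, with a range from 5000 nM to 45000 nM, which is expected to mean a 1.7-fold lower number from compound 1 to compound 4 (0.23 log units; within the scatter).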

Compound 4, solubility: < 5000 nM
Compound 4 was reported as a limit; the forecaster's own chance of this, stated with the estimate: 25%; at least 2.8-fold (0.44 log units) between middle value and limit.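

Compound 4 sits at a limit in this assay, < 5000 nM, and this is not a number. Among the compounds shown here, on the aromatic carbon, para to a large group, cyano in place of 4-fluorophenoxy gives an at least 4.7-fold lower number from compound 1 to compound 4 (0.67 log units; beyond the scatter), so the sign left open by the earlier compounds now reads downward for this one pair, and the step is beyond the scatter even at its floor. The other readable step, an at least 1.1-fold lower number from compound 2 to compound 4 (0.05 log units; that floor lies within the scatter), shows only a floor within the scatter, and steps between the two limited compounds cannot be read, so the measured spread now rests on compound 1 and compound 2 alone, with limits making up the rest of the set: the limit of < 5000 nM in this assay, at which 2 of the 4 values shown sit.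

As far as these compounds go, the true distance from compound 1 to compound 4 stays unknown, and a single pair cannot tell whether the higher number of compound 1 goes with the 4-fluorophenoxy group in particular or with any large group on that aromatic carbon. Plain phenoxy, a morpholine or a carboxylic acid on the same carbon would separate these readings, and the shared core itself is untouched by any step shown here.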